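From compound 3 to compound 4: ring to open chain

A few compounds are considered here, and "the series" means these few. Any claim that something is new, unique, unknown or untested is made for them only; others in the source may bear on it.

Three related compounds have numbers in a functional assay on CAL-51 cells (Homo sapiens) for inhibition, read by luminescence, with a stated time of 3 days; a higher number here means a weaker inhibitor, a lower number a stronger inhibitor. Compound 1 `CCc1cccc(CC)c1NC(=O)c1cc(-c2nc(Nc3ccc(N4CCC(N5CCN(C)CC5)CC4)cc3OC)nc3[nH]ccc23)n(C)n1` gives 17 nM, compound 2 `CCc1cccc(CC)c1N1CCn2cc(-c3nc(Nc4ccc(N5CCC(N6CCN(C)CC6)CC5)cc4OC)nc4[nH]ccc34)cc2C1=O` gives 9 nM and compound 3 `CCc1cccc(CC)c1N1CCn2cc(-c3nc(Nc4ccc(N5CCC(C(=O)N6CCN(C)CC6)CC5)cc4OC)nc4[nH]ccc34)cc2C1=O` gives 5 nM. Compound 3 holds the lowest of the three numbers, but only compound 1 lies beyond the scatter from it; compound 2 lies within the scatter.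

Compound 4 `CCc1cccc(CC)c1N1CCn2cc(-c3nc(Nc4ccc(N5CCC(C(=O)N(C)CCN(C)C)CC5)cc4OC)nc4[nH]ccc34)cc2C1=O` differs from compound 3 in one place: (2-(dimethylamino)ethyl)(methyl)amino in place of 4-methylpiperazin-1-yl on a carbonyl carbon. In words, (2-(dimethylamino)ethyl)(methyl)amino stands in place of 4-methylpiperazin-1-yl on a carbonyl carbon, so the ring gives way to an open chain.

Going by the values given here, one measured step bears on this change, and only indirectly: a 1.8-fold lower number from compound 2 to compound 3 (0.26 log units; within the scatter). It brings in (4-methylpiperazin-1-yl)carbonyl in place of 4-methylpiperazin-1-yl on a saturated ring carbon, and it stays within the scatter. Among the compounds with values here, no measured pair compares this ring with this open chain directly, so the data set no direction. On that single step, no change beyond the scatter is expected in this assay. The expected step is a 1.2-fold higher number from compound 3 to compound 4 (0.08 log units; within the scatter). Compound 4 is estimated at 6 nM, with an expected range from 2.5 nM to 15 nM.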

Compound 4, half-maximal inhibitory concentration: 7 nM
The estimate for compound 4 lay 1.2-fold (0.07 log units) below the measured number, and the stated range covers the measured number.
By their numbers in this assay, from the lowest: compounds 3, 4, 2 and 1 (each within the scatter of the next, the first and the last beyond it).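

Working notes: on the carbonyl carbon whose other neighbour is a saturated ring carbon, replacing 4-methylpiperazin-1-yl with (2-(dimethylamino)ethyl)(methyl)amino removes the ring but keeps the same heavy-atom count. In this assay this change gives a 1.4-fold higher number from compound 3 to compound 4 (0.15 log units; within the scatter) and so shows that, in this pair, opening the ring leaves the number within the scatter. Set against the 4-methylpiperazin-1-yl group placed directly on the saturated ring carbon, (2-(dimethylamino)ethyl)(methyl)carbamoyl gives a 1.3-fold lower number from compound 2 to compound 4 (0.11 log units; within the scatter) and adds a third compound with the same side-chain region changed, again without a step beyond the scatter. No measurement is available to explain why the ring and the open chain read alike here.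

Still open, from the compounds shown here alone, is whether the terminal dimethylamino group matters at this position, a question that a chain ending in a hydroxyl group or a longer chain carrying the same amine would address. Also open, going by these compounds, is whether (2-(dimethylamino)ethyl)(methyl)carbamoyl behaves the same way on the core of compound 1.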